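The source may report more compounds than this note shows. Statements on the series, on what has been measured and on what is new or still open speak of the compounds shown alone.

Among the measured compounds shown here, compound 1, `COc1cccc2c1OCN(c1ccc3oc(-c4ccccc4)cc(=O)c3c1)C2`, stands highest of the two compounds measured so far. In a functional assay on MCF7 cells (Homo sapiens) for inhibition, read by MTT assay, with a stated time of 48 h, tested at 60 ug/mL (on this read-out higher numbers stand for more inhibition of growth at the one concentration tested and lower numbers for less inhibition of growth), compound 1 gives 91.9%. Its nearest neighbour is compound 2, `O=c1cc(-c2ccccc2)oc2ccc(N3COc4c(Br)cccc4C3)cc12`, which in this assay gives 81.8%; the step of a number 10.1 percentage points lower from compound 1 to compound 2 (beyond the scatter) is a modest drop that arises from bromo in place of methoxy on an aromatic carbon.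

Compound 3, `COc1cc2c(c(OC)c1)OCN(c1ccc3oc(-c4ccccc4)cc(=O)c3c1)C2`, is not yet measured. It differs from compound 1 in one place: methoxy in place of hydrogen on an aromatic carbon, so compound 3 carries a second methoxy on the same ring. For the measured compounds named here, no measured step covers this addition directly; the only step at hand, a number 10.1 percentage points lower from compound 1 to compound 2 (beyond the scatter), exchanges one group for another rather than adding a group, and it shows that a change at this ring moves the number only modestly. Compound 1 already sits near the top of the scale, leaving little room upward. Compound 3 is therefore expected to stay close to compound 1, with the step of a number 3.9 percentage points lower from compound 1 to compound 3 (within the scatter) estimated to fall within the scatter. The estimate for compound 3 is 88%, with a range from 72% to 97%.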

Compound 3, percent growth inhibition at one concentration: 99.1%
For compound 3 the middle estimate is 11.1 percentage points below the measured one, and the stated range ends below it.
By their numbers in this assay, from the lowest: compound 2; then compounds 1 and 3 (each within the scatter of the next).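

Placing methoxy in place of hydrogen on this aromatic carbon, meta to a methoxy group and para to a fused ring, gives a number 7.2 percentage points higher from compound 1 to compound 3 (within the scatter) in this assay, so this position accepts a second methoxy with no change that can be told from the scatter. Unlike the earlier step, which exchanged one group for another at a different place, this one adds a group to the ring, and with compound 3 at 99.1% the read-out, taken at one concentration, has almost no room left to show any further gain. The compounds shown offer no measurement that explains this result.

On these data alone, what remains open is whether this position would tolerate groups of another kind, such as a hydroxy group, an amine or a carboxylic acid, or a longer chain such as butoxy, as readily as it tolerates methoxy. Also open, as far as these compounds go, is whether compound 1 and compound 3 would separate at lower concentrations, where the read-out would no longer sit so close to the top of its scale.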